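Swapping Ethyl for 2-Methylbenzyl on the Sulfur Chain

The compounds below may be only part of what the source reports. "The series", "measured", "known", "first", "only" and "open" are said of these compounds alone.

Two compounds share a core and differ only in the chain attached to a sulfur. Compound 1 `CCCCSc1n[nH]c(-n2[se]c3ccccc3c2=O)n1` carries a butyl chain, and in a functional assay on HeLa cells (Homo sapiens) for antiproliferative activity, read by CCK-8 assay, with a stated time of 48 h (a higher number here means a weaker inhibitor, a lower number a stronger inhibitor), compound 1 gives 32900 nM. Compound 2 `CCSc1n[nH]c(-n2[se]c3ccccc3c2=O)n1` carries an ethyl chain instead; in this assay compound 2 gives 14100 nM. Among the compounds with values here, the step of a 2.3-fold lower number from compound 1 to compound 2 (0.37 log units; beyond the scatter) is a modest gain, and compound 2 holds the lowest of the two numbers measured so far.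

Compound 3 `Cc1ccccc1CSc1n[nH]c(-n2[se]c3ccccc3c2=O)n1` alters the same chain in a different way: 2-methylphenyl in place of methyl on a saturated chain carbon bound to a sulfur. Cut one bond further out, the difference reads ethyl to 2-methylbenzyl. Within the data shown here, only one measured step bears on this, a 2.3-fold lower number from compound 1 to compound 2 (0.37 log units; beyond the scatter), and it concerns a longer saturated chain rather than an added aromatic ring, so it is a weak guide. Because the step of a 2.3-fold lower number from compound 1 to compound 2 (0.37 log units; beyond the scatter) shows the larger chain of compound 1 going with the higher number, the expected step for compound 3 is a modest upward move of a 1.6-fold higher number from compound 2 to compound 3 (0.19 log units; within the scatter). A result within the scatter of compound 2 would not surprise. The estimate for compound 3 in this assay is 22000 nM, with a range from 7000 nM to 70000 nM.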

Compound 3, half-maximal inhibitory concentration: 6130 nM
Compound 3: the middle estimate sits 3.6-fold (0.55 log units) above what was measured, and the stated range ends above it.
By their numbers in this assay, from the lowest: compound 3; then compound 2; then compound 1.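

The chain on the sulfur does not simply favour small groups. With 2-methylphenyl in place of methyl on a saturated chain carbon bound to a sulfur, this assay gives a 2.3-fold lower number from compound 2 to compound 3 (0.36 log units; beyond the scatter), and replacing propyl at that same carbon gives a 5.4-fold lower number from compound 1 to compound 3 (0.73 log units; beyond the scatter). The earlier pair held only saturated chains, with the shorter ethyl of compound 2 giving a lower number than the butyl of compound 1, but compound 3 goes against that trend by carrying the largest group of the three and giving the lowest number, so group size alone does not order these compounds. No measurement in hand accounts for this order, so the data show the size of the change but not its origin.

The compounds shown leave open whether the aromatic ring alone carries this gain or its methyl also contributes, a question that a plain benzyl group on the sulfur would help to answer. Also open, as far as these compounds go, is how the number would respond to an amine or a carboxylic acid on that ring, or to a longer chain between the sulfur and the ring.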